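The source may report more compounds than this note shows. Statements on the series, on what has been measured and on what is new or still open speak of the compounds shown alone.

Measured compounds:
Compound 1, `COc1ccc(-c2ccc(N(C[C@@H](N)CC(C)C)C(=O)[C@@H]3C[C@H]3c3ccccc3)cc2)cc1`: in a functional assay for agonist activity at G protein-coupled receptor 88 (Homo sapiens), read by HTRF and cAMP accumulation (on this read-out higher numbers stand for an effect only at larger amounts of compound and lower numbers for an effect already at smaller amounts), compound 1 gives 330 nM.
Compound 2, `COc1cccc(-c2ccc(N(C[C@@H](N)CC(C)C)C(=O)[C@@H]3C[C@H]3c3ccccc3)cc2)c1`: compound 2 gives 1100 nM.
Compound 3, `CC[C@H](C)[C@H](N)CN(C(=O)[C@@H]1C[C@H]1c1ccccc1)c1ccc(-c2ccc(OC)cc2)cc1`: compound 3 gives 120 nM.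

Among these three, compound 3 stands at the lowest number. Its nearest neighbour is compound 1, reached by a 2.8-fold lower number from compound 1 to compound 3 (0.44 log units; beyond the scatter), a modest step that comes from the sec-butyl in place of isobutyl on the chain next to the amine. The furthest is compound 2; the step of a 3.3-fold higher number from compound 1 to compound 2 (0.52 log units; beyond the scatter) shows that moving the methoxy on the distal ring already shifts the number modestly.

Compound 4, `CCOC(=O)c1ccc(-c2ccc(N(C[C@@H](N)[C@@H](C)CC)C(=O)[C@@H]3C[C@H]3c3ccccc3)cc2)cc1`, keeps the sec-butyl chain of compound 3 and alters the distal ring: ethoxycarbonyl in place of methoxy on an aromatic carbon. Among the measured compounds shown here, no measured pair changes the nature of the group on that ring, so nothing bears on this step directly. For the measured compounds named here, the step of a 3.3-fold higher number from compound 1 to compound 2 (0.52 log units; beyond the scatter) is the only evidence that the distal ring is sensitive at all, and it was modest. The outcome is therefore expected to be a modest shift in this assay, more likely upward than downward, of about a 2.5-fold higher number from compound 3 to compound 4 (0.40 log units; beyond the scatter), with wide uncertainty. Compound 4 is estimated at 300 nM in this assay, within a range of 80 nM to 1200 nM.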

Compound 4, half-maximal effective concentration: 260 nM
Compound 4: middle estimate off by 1.2-fold (0.06 log units), on the high side, and the stated range covers the measured number.
By their numbers in this assay, from the lowest: compound 3; then compounds 4 and 1 (each within the scatter of the next); then compound 2.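

Among the compounds shown here, the first change of group on the distal ring, rather than a move of the same group, comes at a modest cost in this assay: ethoxycarbonyl in place of methoxy, on an aromatic carbon para to a large group, gives a 2.2-fold higher number from compound 3 to compound 4 (0.34 log units; beyond the scatter). The earlier compounds shown here showed only that shifting methoxy from the 4-methoxyphenyl to the 3-methoxyphenyl arrangement changes the number, through a 3.3-fold higher number from compound 1 to compound 2 (0.52 log units; beyond the scatter); compound 4 adds that this place accepts an entering group of 5 heavy atoms with a double bond outside the aromatic rings, in exchange for one of 2 heavy atoms, and still stays on the same modest scale of change. Nothing at hand explains why the number rises with this replacement.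

The compounds shown leave open how a carboxylic acid, an amine or a longer chain at this same place would read in this assay, so one ester beside one ether does not yet describe what the position prefers. For the compounds shown here, they also leave open whether 4-(ethoxycarbonyl)phenyl would give a step of similar size on the isobutyl chain of compound 1, since this replacement is seen only with the sec-butyl chain.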